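Adding two fluorines to the phenoxy group of compound 3

This account rests on a few compounds, and the source may have more. Where it says the series, first, only, none or still open, it means among the compounds named here.

In a functional assay on MV4-11 cells (Homo sapiens) for antiproliferative activity, read by CCK-8 assay, with a stated time of 72 h (on this read-out lower numbers stand for stronger inhibition and higher numbers for weaker inhibition), compound 1 (`Cn1cc(-c2cccc(C(C)(C)O)c2)c2cc(C(=O)NCc3ccc(C(=O)Nc4ccccc4N)cc3)[nH]c2c1=O`) gives 2200 nM and compound 2 (`COc1ccc(C(C)(C)O)cc1-c1cn(C)c(=O)c2[nH]c(C(=O)NCc3ccc(C(=O)Nc4ccccc4N)cc3)cc12`) gives 420 nM while compound 3 (`Cn1cc(-c2cc(C(C)(C)O)ccc2Oc2ccccc2)c2cc(C(=O)NCc3ccc(C(=O)Nc4ccccc4N)cc3)[nH]c2c1=O`) gives 100 nM as the lowest of the three numbers. The next structure is compound 4 (`Cn1cc(-c2cc(C(C)(C)O)ccc2Oc2ccc(F)cc2F)c2cc(C(=O)NCc3ccc(C(=O)Nc4ccccc4N)cc3)[nH]c2c1=O`), and its difference from compound 3 is 2,4-difluorophenyl in place of phenyl on an oxygen on an aromatic ring with 2,4-difluorophenyl in place of phenyl on an oxygen on an aromatic ring.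

Going by the values given here, three measured steps bear on this change. Methoxy in place of hydrogen on an aromatic carbon gave a 5.2-fold lower number from compound 1 to compound 2 (0.72 log units; beyond the scatter) and phenoxy in the same role gave a 22-fold lower number from compound 1 to compound 3 (1.34 log units; beyond the scatter) while phenyl in place of methyl on an oxygen on an aromatic ring gave a 4.2-fold lower number from compound 2 to compound 3 (0.62 log units; beyond the scatter) in a modest move. All three go to lower numbers, but none of them involves fluorine, so the data give no direct measure for this change.

A small move toward a lower number is expected, within the scatter: an estimated 1.4-fold lower number from compound 3 to compound 4 (0.15 log units; within the scatter) in this assay is the working figure. For compound 4 the estimated value is 70 nM with an expected range from 25 nM to 200 nM around it.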

Compound 4, half-maximal inhibitory concentration: 90 nM
The estimate for compound 4 lay 1.3-fold (0.11 log units) below the measured number; the range from low to high includes it.
By their numbers in this assay, from the lowest: compounds 4 and 3 (each within the scatter of the next); then compound 2; then compound 1.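

In this assay, going by these compounds alone, the first change on the phenoxy ring itself, 2,4-difluorophenyl in place of phenyl on the oxygen, gives a 1.1-fold lower number from compound 3 to compound 4 (0.05 log units; within the scatter) and so separates compound 4 from compound 3 by no more than the scatter. The step from the smaller group holds with the two fluorines in place, with a 4.7-fold lower number from compound 2 to compound 4 (0.67 log units; beyond the scatter) for 2,4-difluorophenyl in place of methyl on the oxygen. The full step holds too, with a 24-fold lower number from compound 1 to compound 4 (1.39 log units; beyond the scatter) for 2,4-difluorophenoxy in place of hydrogen on the aromatic carbon, and nothing available accounts for any of these results.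

Open, from the compounds shown here alone, is how the phenoxy ring responds to an amine or a carboxylic acid in place of the fluorines. Also open, going by these compounds, is whether a single fluorine reads like the pair.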